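Hydroxy added to the anilino group of compound 2

This account rests on a few compounds, and the source may have more. Where it says the series, first, only, none or still open, it means among the compounds named here.

Among the compounds with values here, in a functional assay on EOL1 cells (Homo sapiens) for inhibition, read by fluorescence, with a stated time of 72 h (on this read-out lower numbers stand for stronger inhibition of growth and higher numbers for weaker inhibition of growth), compound 2 (`CC(C)CCn1cnc2c(Nc3ccccc3)nc(N[C@H]3CC[C@H](N)CC3)nc21`) gives 10 nM and holds the lower of the two numbers so far, while compound 1 (`N[C@H]1CC[C@H](Nc2nc(Nc3ccc(O)cc3)c3ncn(C4CCCCC4)c3n2)CC1`) gives 220 nM on the same read-out. Compound 3 (`CC(C)CCn1cnc2c(Nc3ccc(O)cc3)nc(N[C@H]3CC[C@H](N)CC3)nc21`) departs from compound 2 through hydroxy in place of hydrogen on an aromatic carbon (hydroxy in place of hydrogen on an aromatic carbon, phenyl to 4-hydroxyphenyl). Within the data shown here, no measured pair shows this change alone. Compound 1 also carries 4-hydroxyphenyl, but its number cannot isolate the change. A modest step toward a higher number in this assay is expected, possibly none beyond the scatter. The estimate is a 1.8-fold higher number from compound 2 to compound 3 (0.26 log units; within the scatter) for this change. For compound 3 the expected value is 18 nM (estimated range 4 nM to 80 nM).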

Compound 3, concentration for 50% growth inhibition: 30 nM
For compound 3 the middle estimate is 1.7-fold (0.22 log units) below the measured one, within the range that was stated.
By their numbers in this assay, from the lowest: compound 2; then compound 3; then compound 1.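

In this assay, phenyl to 4-hydroxyphenyl can now be read on its own: the change gives a 3.0-fold higher number from compound 2 to compound 3 (0.48 log units; beyond the scatter), so this place on the ring accepts hydroxy but does not leave the number unchanged. With 4-hydroxyphenyl held constant, isopentyl in place of cyclohexyl on the aromatic nitrogen gives a 7.3-fold lower number from compound 1 to compound 3 (0.87 log units; beyond the scatter). The data offer no explanation for either step.

Still open, on these data alone, is how an amine or a methoxy group in place of that hydroxy would read. Also open, as far as these compounds go, is whether hydroxy gives the same step with cyclohexyl on the nitrogen.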